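The source may report more compounds than this note shows. Statements on the series, on what has been measured and on what is new or still open speak of the compounds shown alone.

Compound 1 `O=C(NNC(=O)c1ccc2[nH]c(-c3ccc([N+](=O)[O-])o3)nc2c1)c1ccccc1`: 15.6 ug/mL
Compound 2 `COc1cc(C(=O)NNC(=O)c2ccc3[nH]c(-c4ccc([N+](=O)[O-])s4)nc3c2)cc(OC)c1OC`: 31.3 ug/mL

These two compounds were tested in a functional assay on K562 cells (Homo sapiens) for inhibition, read by sulforhodamine B assay, with a stated time of 48 h; on this read-out lower numbers stand for stronger inhibition of growth and higher numbers for weaker inhibition of growth. Compound 1 gives 15.6 ug/mL and compound 2 gives 31.3 ug/mL. Going by the values given here, the two values lie within the usual scatter of each other, so compound 1 stands level with the only other compound measured so far. Two numbers are too few to show a trend.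

Compound 3 `COc1cccc(C(=O)NNC(=O)c2ccc3[nH]c(-c4ccc([N+](=O)[O-])o4)nc3c2)c1` keeps the shared core of compound 1 and differs at one place: methoxy in place of hydrogen on an aromatic carbon. This puts methoxy in place of hydrogen on an aromatic carbon, turning phenyl into 3-methoxyphenyl. Among the compounds with values here, no measured pair isolates this change. Compound 2, at 31.3 ug/mL, also carries methoxy groups but differs from compound 1 elsewhere too, so it offers only a weak guide.

With so little evidence, no change beyond the scatter is expected in this assay. The expected change is small: a 1.2-fold higher number from compound 1 to compound 3 (0.06 log units; within the scatter). For compound 3 the estimated value is 18 ug/mL, with an expected range of 7 ug/mL to 45 ug/mL.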

Compound 3, concentration for 50% growth inhibition: 15.6 ug/mL
For compound 3 the middle estimate is 1.2-fold (0.06 log units) above the measured one; measured number inside the range.
By their numbers in this assay, from the lowest: compounds 1, 3 and 2 (each within the scatter of the next).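

In this assay, turning phenyl into 3-methoxyphenyl on the shared core gives no change at the digits printed from compound 1 to compound 3 (within the scatter). Going by these compounds alone, this is the first pair here that differs in one place only, so the methoxy group can be judged on its own: at this position on the six-membered aromatic ring, adding these two heavy atoms leaves the growth-inhibition reading where it was, as far as this assay can tell. Compound 2 could not show this, since it carries methoxy groups but also differs from compound 1 elsewhere; still, nothing measured here explains why the reading holds steady.

On these data alone, one methoxy group at one place is a narrow test, so it remains open whether this position would accept a group of a different kind, such as an amine, a carboxylic acid or a longer chain like butoxy, with the same result. As far as these compounds go, it also remains open whether a methoxy group on another carbon of the same ring would read the same, and whether any change at this ring can move the number beyond the usual scatter at all.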